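Swapping Bromo for Methyl on the Anilide Ring

The compounds below may be only part of what the source reports. "The series", "measured", "known", "first", "only" and "open" are said of these compounds alone.

compound 1 `CN1C[C@H](C(=O)Nc2ccc(C#N)cc2)[C@@H](c2ccc(/C=C/C(=O)Nc3ccccc3N)cc2)C1`: 35 mL/min/kg
compound 2 `CN1C[C@H](C(=O)Nc2ccc(C(F)(F)F)cc2)[C@@H](c2ccc(/C=C/C(=O)Nc3ccccc3N)cc2)C1`: 23 mL/min/kg
compound 3 `CN1C[C@H](C(=O)Nc2ccc(Br)cc2)[C@@H](c2ccc(/C=C/C(=O)Nc3ccccc3N)cc2)C1`: 16 mL/min/kg

These three compounds were tested in an in vitro ADME assay on microsomes from liver (Mus musculus) for pharmacokinetics, read by LC-MS, with a stated time of 10 min, tested at 1 uM (a lower number here means slower removal, a higher number faster removal of the compound), and they differ in a single group on an aromatic carbon. Compound 3 stands within the scatter of compound 2 but clearly apart from compound 1.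

Compound 4 `Cc1cccc(NC(=O)[C@H]2CN(C)C[C@@H]2c2ccc(/C=C/C(=O)Nc3ccccc3N)cc2)c1` has not yet been measured. Its change from compound 3 is 3-methylphenyl in place of 4-bromophenyl on an amide-type nitrogen. For the measured compounds named here, three measured steps bear on this, though none involves a 3-methylphenyl group. Two stay within the scatter: a 1.5-fold lower number from compound 1 to compound 2 (0.18 log units; within the scatter) and a 1.4-fold lower number from compound 2 to compound 3 (0.16 log units; within the scatter). Only a 2.2-fold lower number from compound 1 to compound 3 (0.34 log units; beyond the scatter) passes it, and that step is modest. Swaps in this part of the molecule have therefore moved the number only a little, and leaving bromo may give a little of that back. The expected shift is a 1.5-fold higher number from compound 3 to compound 4 (0.18 log units; within the scatter), a slight rise in the number. For compound 4 the estimated clearance is 24 mL/min/kg, with an expected range from 12 mL/min/kg to 48 mL/min/kg.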

Compound 4, clearance: 74 mL/min/kg
Compound 4: the middle estimate sits 3.1-fold (0.49 log units) below what was measured, outside the stated range (above it).
By their numbers in this assay, from the lowest: compounds 3, 2 and 1 (each within the scatter of the next, the first and the last beyond it); then compound 4.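

In this assay the aromatic group on the amide-type nitrogen matters more than the cyano, trifluoromethyl and bromo compounds suggested: 3-methylphenyl brings a 4.6-fold higher number from compound 3 to compound 4 (0.67 log units; beyond the scatter) and also a 3.2-fold higher number from compound 2 to compound 4 (0.51 log units; beyond the scatter) as well as a 2.1-fold higher number from compound 1 to compound 4 (0.33 log units; beyond the scatter) in the same direction. Compound 4 therefore stands above all three earlier compounds, with every step beyond the scatter, so this position can move removal further than those compounds showed. Nothing available here explains the rise.

This one change alters both the group and its printed ring position, and the compounds shown cannot tell which of the two goes with the higher number. A 4-methylphenyl or a 3-bromophenyl group would separate them, while a plain phenyl or a 3-methoxyphenyl group would show how far the trend extends.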